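From Compound 2 to Compound 3: One Small Change

A few compounds are considered here, and "the series" means these few. Any claim that something is new, unique, unknown or untested is made for them only; others in the source may bear on it.

Compound 1 `CC/C(=C(/c1ccc(/C=C/C(=O)O)cc1)c1ccc2nnnn2c1)c1ccccc1`: > 500 nM (a limit)
Compound 2 `CC/C(=C(/c1ccc(/C=C/C(=O)O)cc1)c1ccc2sncc2c1)c1ccccc1`: > 500 nM (a limit)

In a functional assay on MCF7 cells (Homo sapiens) for antiproliferative activity, read by CellTiter-Glo, with a stated time of 5 days (a lower number here means a stronger inhibitor, a higher number a weaker inhibitor), compound 2 gives > 500 nM, which is a limit and not a number. Compound 1 gives > 500 nM, which is also a limit. The whole record so far is the limit of > 500 nM in this assay, at which 2 of the 2 values shown sit.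

Compound 3 `CC/C(=C(/c1ccc(/C=C/C(=O)O)cc1)c1ccc2sc(C)nc2c1)c1ccccc1` differs from compound 2 in one place: a group of 10 heavy atoms (8 carbon, 1 nitrogen, 1 sulfur; one five-membered aromatic ring with 2 hetero atoms, one six-membered aromatic ring of carbon only) in place of a group of 9 heavy atoms (7 carbon, 1 nitrogen, 1 sulfur; one five-membered aromatic ring with 2 hetero atoms, one six-membered aromatic ring of carbon only), on a double-bonded chain carbon bound to an aromatic carbon and a double-bonded chain carbon. The entering group is 2-methyl-1,3-benzothiazol-5-yl, and it sits on a double-bonded chain carbon bound to an aromatic carbon and a double-bonded chain carbon.

Among the compounds with values here, only one measured step bears on this change, as it alters the same place: a step that the two limits leave unreadable from compound 1 to compound 2. That step has no readable size, so it cannot show how strongly this assay responds to changes here. With the step that the two limits leave unreadable from compound 1 to compound 2 unreadable, no change beyond the usual scatter is expected. The expected step is a step that the limit leaves unreadable from compound 2 to compound 3, and this is only an estimate. Compound 3 is estimated at 800 nM, with an expected range of 250 nM to 2500 nM.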

Compound 3, half-maximal inhibitory concentration: > 500 nM
Compound 3: only a limit was reported (the forecaster's own chance of this, stated with the estimate: 70%); the middle value lies beyond the limit too.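

In this assay compound 3 gives > 500 nM, which is a limit and not a number. Within the data shown here, no step to compound 3 from compound 1 or compound 2 can be read. The compounds shown leave open how strong each one really is, and whether 2-methyl-1,3-benzothiazol-5-yl changes anything, as all stop at the same point: the limit of > 500 nM in this assay, at which 3 of the 3 values shown sit.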